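The compounds below may be only part of what the source reports. "The series", "measured", "known", "first", "only" and "open" are said of these compounds alone.

Compound 1 `COc1cc(-c2nnc3n2NC(c2cccs2)C(C(=O)c2ccccc2)S3)cc(OC)c1OC`: 69400 nM
Compound 2 `COc1cc(-c2nnc3n2NC(c2ccco2)C(C(=O)c2cccc(Br)c2)S3)cc(OC)c1OC`: 36900 nM
Compound 3 `COc1ccc(C(=O)C2Sc3nnc(-c4cc(OC)c(OC)c(OC)c4)n3NC2c2cccs2)cc1`: > 100000 nM

In a functional assay on A549 cells (Homo sapiens) for cytotoxicity, read by MTT assay, with a stated time of 48 h (a higher number here means a weaker inhibitor, a lower number a stronger inhibitor), compound 2 gives 36900 nM, and compound 1 gives 69400 nM; the two numbers lie within the usual scatter of each other, so neither can be set ahead of the other. For compound 3 the assay reports only a limit, (the limit of > 100000 nM in this assay, at which 1 of the 3 values shown sits), and no number. The step from compound 1 to compound 3, methoxy in place of hydrogen on an aromatic carbon, accordingly reads as an at least 1.4-fold higher number from compound 1 to compound 3 (0.15 log units; that floor lies within the scatter).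

Compound 4 `COc1cccc(C(=O)C2Sc3nnc(-c4cc(OC)c(OC)c(OC)c4)n3NC2c2ccco2)c1` has not yet been measured. It differs from compound 2 in one place: methoxy in place of bromo on an aromatic carbon. Within the data shown here, the only measured step that touches on it is an at least 1.4-fold higher number from compound 1 to compound 3 (0.15 log units; that floor lies within the scatter), where a methoxy also enters an aromatic carbon, though there it replaces hydrogen rather than bromo; that step ran toward a weaker inhibitor and ended at a limit. On this slender basis the writer expects a step toward a higher number in this assay, of the order a 1.9-fold higher number from compound 2 to compound 4 (0.28 log units; within the scatter), with a fair chance that the assay again reports only a limit. Compound 4 is therefore estimated at 70000 nM, within 30000 nM to 200000 nM.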

Compound 4, half-maximal inhibitory concentration: > 100000 nM
Compound 4: no number, only a limit (the forecaster's own chance of this, stated with the estimate: 35%); middle value at least 1.4-fold (0.15 log units) from the limit.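

In this assay, the change from 3-bromophenyl to 3-methoxyphenyl gives an at least 2.7-fold higher number from compound 2 to compound 4 (0.43 log units; beyond the scatter), and this is the first step shown that lies beyond the scatter. Among these compounds, the earlier methoxy step, an at least 1.4-fold higher number from compound 1 to compound 3 (0.15 log units; that floor lies within the scatter), replaced hydrogen rather than bromo and could not be told from the scatter, so the new step is the first firm sign that the group at this place on the benzoyl ring matters, with bromo the better of the two. Compound 4 gives only a limit, so the step is a floor and its full size stays unknown: the limit of > 100000 nM in this assay, at which 2 of the 4 values shown sit.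

The compounds shown leave open whether an amine, a carboxylic acid or a chloro group at this place would give a number lower than that of compound 2. They also leave open how hydrogen at this place would compare with bromo and methoxy.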